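Ester aryl variation in the flavone ether series

The compounds below may be only part of what the source reports. "The series", "measured", "known", "first", "only" and "open" are said of these compounds alone.

Among the compounds with values here, compound 2 `COC(=O)c1c(Cl)cccc1OC(=O)COc1cc(O)c2c(=O)cc(-c3ccccc3)oc2c1` gives 38900 nM in a functional assay on cells (T-cell, Mus musculus, strain BALB/c) for inhibition, read by MTT assay, with a stated time of 72 h (a lower number here means a stronger inhibitor, a higher number a weaker inhibitor), the highest of the two numbers measured so far; compound 1 `COC(=O)c1ccc(C)cc1OC(=O)COc1cc(O)c2c(=O)cc(-c3ccccc3)oc2c1` gives 31100 nM, which lies within the scatter of compound 2. Compound 3 `COC(=O)c1cc(C)ccc1OC(=O)COc1cc(O)c2c(=O)cc(-c3ccccc3)oc2c1` has not been measured; it differs from compound 2 as follows: a group of 11 heavy atoms (9 carbon, 2 oxygen; one six-membered aromatic ring of carbon only) in place of a group of 11 heavy atoms (8 carbon, 2 oxygen, 1 chlorine; one six-membered aromatic ring of carbon only), on an oxygen next to a carbonyl group. Within the data shown here, the only measured step that bears on this, a 1.3-fold higher number from compound 1 to compound 2 (0.10 log units; within the scatter), is a swap of the same kind on the oxygen next to a carbonyl group and stayed within the scatter, so no step beyond the scatter is expected in this assay. The step expected is a 1.2-fold lower number from compound 2 to compound 3 (0.07 log units; within the scatter). Compound 3 is estimated at 33000 nM, within 15000 nM to 70000 nM.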

Compound 3, half-maximal inhibitory concentration: 25700 nM
Estimate against measurement, compound 3: 1.3-fold (0.11 log units) above, within the range that was stated.
By their numbers in this assay, from the lowest: compounds 3, 1 and 2 (each within the scatter of the next).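

On an oxygen next to a carbonyl group, replacing the 3-chloro-2-(methoxycarbonyl)phenyl group with the chlorine-free group leaves this assay flat, with a 1.5-fold lower number from compound 2 to compound 3 (0.18 log units; within the scatter). Exchanging two groups of identical atom composition at this place also gives no separable change, with a 1.2-fold lower number from compound 1 to compound 3 (0.08 log units; within the scatter). The three aryl esters therefore cannot be told apart in this assay, and no measurement offered here bears on a cause.

Open, going by these compounds, is whether an amine or a carboxylic acid on this aromatic ring, or a longer chain in place of the methyl ester, would produce a step beyond the scatter.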